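Replacing the pyridine amide with benzamide in a cytotoxicity series

This account rests on a few compounds, and the source may have more. Where it says the series, first, only, none or still open, it means among the compounds named here.

Compound 1 `O=C(Nn1c(-c2cccc([N+](=O)[O-])c2)nc2c(-c3ccc(Cl)cc3)n[nH]c2c1=O)c1cccnc1`: 16.3%
Compound 2 `O=C(Nn1c(-c2cccc([N+](=O)[O-])c2)nc2c(-c3ccc(F)cc3)n[nH]c2c1=O)c1cccnc1`: 24.5%
Compound 3 `O=C(Nn1c(-c2cccc([N+](=O)[O-])c2)nc2c(CCc3ccccc3)n[nH]c2c1=O)c1cccnc1`: 28.5%

In a functional assay on SK-MEL-2 cells (Homo sapiens) for cytotoxicity, read by sulforhodamine B assay, with a stated time of 2 days, tested at 100 uM (on this read-out higher numbers stand for more inhibition at the one concentration tested (going by the name of the read-out) and lower numbers for less inhibition), compound 2 sits second highest of the three numbers. Its steps to the others are small: a number 8.2 percentage points higher from compound 1 to compound 2 (within the scatter) and a number 4 percentage points higher from compound 2 to compound 3 (within the scatter) both lie within the scatter, while only a number 12.2 percentage points higher from compound 1 to compound 3 (beyond the scatter) reaches beyond it.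

Compound 4 `O=C(Nn1c(-c2cccc([N+](=O)[O-])c2)nc2c(-c3ccc(F)cc3)n[nH]c2c1=O)c1ccccc1` differs from compound 2 by phenyl in place of pyridin-3-yl on a carbonyl carbon. Within the data shown here, no measured step touches this carbonyl position; all three measured steps alter the group on the aromatic carbon of the shared core. There is therefore no measured guide for this change, and a step of a number 0.5 percentage points lower from compound 2 to compound 4 (within the scatter) within the scatter is expected. For compound 4 the value in this assay is estimated at 24%, within 10% to 40%.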

Compound 4, a percentage reported as inhibition, at one concentration (the size of the read-out at that concentration, not a potency): 88.5%
The estimate for compound 4 lay 64.5 percentage points below the measured number, and the stated range ends below it.
By their numbers in this assay, from the lowest: compounds 1, 2 and 3 (each within the scatter of the next, the first and the last beyond it); then compound 4.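

In this assay, phenyl in place of pyridin-3-yl on the carbonyl carbon gives a number 64 percentage points higher from compound 2 to compound 4 (beyond the scatter), a far larger step than any seen among compounds 1, 2 and 3 at the group on the aromatic carbon. The two groups have the same number of heavy atoms and differ by one ring nitrogen, so a single-atom change at this position can move the number greatly. Nothing available explains why.

On these data alone, it remains open whether the benzamide gives a similar rise with the 4-chlorophenyl or phenethyl group in place of 4-fluorophenyl. As far as these compounds go, how a cyclohexyl ring or a methoxy-substituted phenyl would read on this carbonyl is also open.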